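Swapping a Fluoropyridine for a Fluorophenyl on a Tolerated Scaffold

The source may report more compounds than this note shows. Statements on the series, on what has been measured and on what is new or still open speak of the compounds shown alone.

Compound 1, with structure `CS(=O)(=O)Nc1ccc2c(c1)S(=O)(=O)N=C(C1=C(O)C3CCCC3N(Cc3ccc(F)cn3)C1=O)N2`, was examined in an ADME assay on Huh-7 cells (Homo sapiens) for cytotoxicity, with a stated time of 72 h; a lower number here means that less compound is tolerated, a higher number that more compound is tolerated. There compound 1 gives only a limit, > 33000 nM, so no exact number is known for it. A second compound, compound 2 with structure `CS(=O)(=O)Nc1ccc2c(c1)S(=O)(=O)N=C(C1=C(O)C3CCCCCCC3N(Cc3ccc(F)cc3)C1=O)N2`, differs from compound 1 in more than one place. In this assay compound 2 also gives only a limit, > 33000 nM. Compound 1 therefore stands where every value shown stands, at the edge of what the assay can report: the limit of > 33000 nM in this assay, at which 2 of the 2 values shown sit.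

Compound 3, with structure `CS(=O)(=O)Nc1ccc2c(c1)S(=O)(=O)N=C(C1=C(O)C3CCCC3N(Cc3cccc(F)c3)C1=O)N2`, is not yet measured. It is related to compound 1 by a single change: 3-fluorophenyl in place of 5-fluoropyridin-2-yl on a saturated chain carbon bound to an amide-type nitrogen in a ring. Among the compounds with values here, no measured pair in this set shows what such a swap does to tolerated concentration. Because the limit of > 33000 nM in this assay, at which 2 of the 2 values shown sit, describes every value shown, the most plausible expectation for compound 3 is that it also reaches the limit. The step of a number no higher from compound 1 to compound 3 (the limit leaves the size open) is expected to be none beyond the scatter. Compound 3 is therefore estimated at 33000 nM, with a range from 20000 nM to 60000 nM.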

Compound 3, half-maximal cytotoxic concentration: > 33000 nM
Compound 3: a limit, no number (the forecaster's own chance of this, stated with the estimate: 85%); the middle value lies on the limit itself.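

In this assay, within the data shown here, compound 3 gives only a limit, as compound 1 does, so no step between compound 1 and compound 3 can be read. The compounds shown leave open at what concentration any of them would begin to harm these cells, since all stop at the same edge: the limit of > 33000 nM in this assay, at which 3 of the 3 values shown sit.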